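Swapping an ester side chain on a quinone core

The compounds below may be only part of what the source reports. "The series", "measured", "known", "first", "only" and "open" are said of these compounds alone.

Three compounds share one core and differ only in the ester group attached to it. Compound 1 `CC(=O)OCCC(=O)O[C@H](CC=C(C)C)C1=CC(=O)c2c(O)ccc(O)c2C1=O` gives 15700 nM in a functional assay on DU-145 cells (Homo sapiens) for cytotoxicity, read by MTT assay; on this read-out lower numbers stand for stronger inhibition and higher numbers for weaker inhibition. Compound 2 `CC(C)=CC[C@@H](OC(=O)C1CCCO1)C1=CC(=O)c2c(O)ccc(O)c2C1=O` gives 10500 nM, and compound 3 `CC(C)=CC[C@@H](OC(=O)CC(C)(O)C(C)C)C1=CC(=O)c2c(O)ccc(O)c2C1=O` gives 16900 nM. Compound 3 stands at the top of the three numbers, yet only inside the scatter, as a 1.1-fold higher number from compound 1 to compound 3 (0.03 log units; within the scatter) and a 1.6-fold higher number from compound 2 to compound 3 (0.21 log units; within the scatter) show. Compound 4 `CCCCC(CC(=O)O[C@H](CC=C(C)C)C1=CC(=O)c2c(O)ccc(O)c2C1=O)OC(C)=O` is not yet measured; it differs from compound 3 by 1-acetoxypentyl in place of 1-hydroxy-1,2-dimethylpropyl on a saturated chain carbon bound to a carbonyl carbon. Going by the values given here, the one measured step that touches this place, where an acetoxy-bearing chain faces the hydroxylated one, is a 1.1-fold higher number from compound 1 to compound 3 (0.03 log units; within the scatter). Because a 1.1-fold higher number from compound 1 to compound 3 (0.03 log units; within the scatter) stays within the scatter, the estimate for compound 4 is 15000 nM, between 7000 nM and 32000 nM, meaning an expected 1.1-fold lower number from compound 3 to compound 4 (0.05 log units; within the scatter).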

Compound 4, half-maximal inhibitory concentration: 67700 nM
The estimate for compound 4 lay 4.5-fold (0.65 log units) below the measured number, and the stated range ends below it.
By their numbers in this assay, from the lowest: compounds 2, 1 and 3 (each within the scatter of the next); then compound 4.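

In this assay, earlier changes to this ester side chain stayed within the scatter, whereas 1-acetoxypentyl on this saturated chain carbon brings a clear shift toward weaker inhibition: a 4.0-fold higher number from compound 3 to compound 4 (0.60 log units; beyond the scatter) and a 6.4-fold higher number from compound 2 to compound 4 (0.81 log units; beyond the scatter). Going by these compounds alone, the closest comparison is a 4.3-fold higher number from compound 1 to compound 4 (0.63 log units; beyond the scatter), where butyl in place of hydrogen is the only change and the acetoxy group is present on both sides. Thus, the acetoxy group alone does not set compound 4 apart from compound 1.

No measurement shown explains the shift. Going by these compounds, whether a shorter propyl group or a longer octyl chain in place of butyl would weaken inhibition as well remains open.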